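The compounds below may be only part of what the source reports. "The series", "measured", "known", "first", "only" and "open" are said of these compounds alone.

Measured compounds:
Compound 1 `COc1cc(-c2nn(-c3cccc(NC(=O)c4cccc(C(F)(F)F)c4)c3)cc2-c2ccncc2)ccc1Cl` — in a functional assay on Malme-3M cells (Homo sapiens) for inhibition, read by sulforhodamine B assay, with a stated time of 48 h (a higher number here means that more compound is tolerated, a lower number that less compound is tolerated), compound 1 gives > 50000 nM, which is a limit of the assay.
Compound 2 `O=C(Nc1cccc(-n2cc(-c3ccncc3)c(-c3ccc(Cl)c(O)c3)n2)c1)Nc1cc(C(F)(F)F)cc(C(F)(F)F)c1` — in this assay compound 2 gives 23500 nM.
Compound 3 `COc1cc(-c2nn(-c3cccc(NC(=O)Nc4ccc(Cl)c(C(F)(F)F)c4)c3)cc2-c2ccncc2)ccc1Cl` — in this assay compound 3 gives > 32500 nM, which is a limit of the assay.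

For the measured compounds named here, compound 2 stands as the only number in this assay. The values of compound 1 and compound 3 are limits (the limit of > 50000 nM in this assay, at which 1 of the 3 values shown sits, (the limit of > 32500 nM in this assay, at which 1 of the 3 values shown sits)), so the step that the two limits leave unreadable from compound 1 to compound 3 cannot be read. Compound 4 `O=C(Nc1cccc(-n2cc(-c3ccncc3)c(-c3ccc(Cl)c(O)c3)n2)c1)Nc1cccc(C(F)(F)F)c1` differs from compound 2 by hydrogen in place of trifluoromethyl on an aromatic carbon. Going by the values given here, no measured step covers this change, and no direction can be taken from the data, so no step beyond the scatter is expected in this assay. Compound 4 is estimated at 30000 nM, between 10000 nM and 90000 nM. The expected step of a 1.3-fold higher number from compound 2 to compound 4 (0.11 log units; within the scatter) lies within the scatter.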

Compound 4, concentration lethal to 50% of the cells: > 32500 nM
Compound 4 was reported as a limit; the forecaster's own chance of this, stated with the estimate: 40%; at least 1.0-fold (0.03 log units) between middle value and limit.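

Hydrogen in place of trifluoromethyl on this aromatic carbon gives, in this assay, an at least 1.3-fold higher number from compound 2 to compound 4 (0.14 log units; that floor lies within the scatter). For the compounds shown here, this is the first step at this position that can be read at all, and it gives only a floor, so a larger step is not excluded. The value of compound 4 is a limit, not a number: the limit of > 32500 nM in this assay, at which 2 of the 4 values shown sit.

Going by these compounds, the true size of this step stays open, as does the step from compound 1 to compound 3, which cannot be read. On these data alone, what an amine or a carboxylic acid on this aromatic carbon would give also remains open.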